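Swapping an Aminohexyl Chain for a Fluorobenzyl Group

A few compounds are considered here, and "the series" means these few. Any claim that something is new, unique, unknown or untested is made for them only; others in the source may bear on it.

Compound 1, `O=C(NCc1ccc(F)cc1)c1nc(Br)c2cccnc2c1NCc1ccccc1`, gives > 20000 nM in a functional assay on HCT-116 cells (Homo sapiens) for cytotoxicity, read by MTT assay, with a stated time of 72 h (a higher number here means a weaker inhibitor, a lower number a stronger inhibitor), which is a limit of the assay rather than a number. Compound 2, `COC(=O)CNc1c(C(=O)NCc2ccc(F)cc2)nc(Br)c2cccnc12`, gives > 10000 nM, again a limit. Compound 3, `NCCCCCCNc1c(C(=O)NCc2ccc(F)cc2)nc(Br)c2cccnc12`, gives > 10000 nM, also a limit.

Compound 3 therefore stands at a limit, and the two other values are limits too, so no ordering among the three can be drawn. The three single-change steps, a step that the two limits leave unreadable from compound 1 to compound 2, a step that the two limits leave unreadable from compound 1 to compound 3 and a step that the two limits leave unreadable from compound 2 to compound 3, are all unreadable for this reason; the evidence is the limit of > 10000 nM in this assay, at which 2 of the 3 values shown sit, and (the limit of > 20000 nM in this assay, at which 1 of the 3 values shown sits).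

Compound 4, `O=C(NCc1ccc(F)cc1)c1nc(Br)c2cccnc2c1NCc1ccc(F)cc1`, differs from compound 3 by 4-fluorophenyl in place of 5-aminopentyl on a saturated chain carbon bound to a nitrogen on an aromatic ring. Among the compounds with values here, no measured step bears readably on this change, since every value around it is a limit. With nothing to point either way, the step is expected to be about a step that the limit leaves unreadable from compound 3 to compound 4, that is, none beyond the scatter. Compound 4 is expected to give roughly 20000 nM, with a range from 7000 nM to 60000 nM, and most probably the assay will again report only a limit.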

Compound 4, half-maximal inhibitory concentration: > 20000 nM
Compound 4: no number, only a limit; the forecaster's own chance of this, stated with the estimate: 80%; the middle value sits exactly at the limit.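

In this assay compound 4 gives > 20000 nM, a limit of the assay and not a number. The steps joining compound 4 to compounds 1, 2 and 3 therefore cannot be read: the limit of > 20000 nM in this assay, at which 2 of the 4 values shown sit.

Going by these compounds, whether any of these changes to the shared core alters the result in this assay at all stays open.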